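A Single Halogen Swap on the Compound with the Lowest Number

The source may hold more compounds than are shown below. What is called first, only, known or untested is meant among the compounds shown, and "the series" means these compounds.

Compound 1, `Oc1ccc(Cl)cc1-c1cc(-c2ccccc2Cl)[nH]n1`: 29%
Compound 2, `COc1ccc(-c2cc(-c3cc(OC)ccc3O)[nH]n2)cc1`: 82%
Compound 3, `Cc1ccc(O)c(-c2cc(-c3cccc(Br)c3)[nH]n2)c1`: 75%

Of the compounds shown here, three built on the same core have been measured in an assay on isolated protein for inhibition of Polyunsaturated fatty acid lipoxygenase ALOX15 (Homo sapiens), read by spectrophotometry, tested at 20 uM; a higher number here means more inhibition at the concentration tested (going by the name of the read-out), a lower number less inhibition. Compound 1 stands lowest of the three. Its nearest neighbour on the numbers, compound 3, sits higher by a margin beyond the usual scatter, and compound 2 sits higher still, also beyond the scatter. For the measured compounds named here, since no two measured compounds differ from each other in only one place, none of these gaps can be tied to a single structural change.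

Compound 4, `Oc1ccc(Br)cc1-c1cc(-c2ccccc2Cl)[nH]n1`, has not been measured. It differs from compound 1 in one place: bromo in place of chloro on an aromatic carbon. Exchanging one halogen for another of the same kind at the same spot is a small alteration, and in this assay the expected step is small, at most a mild rise, and likely within the scatter. Compound 4 is therefore expected to give about 35%, with a plausible range from 15% to 55%. This corresponds to an expected step of a number 6 percentage points higher from compound 1 to compound 4 (within the scatter).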

Compound 4, a percentage reported as inhibition, at one concentration (the size of the read-out at that concentration, not a potency): 32%
Compound 4: middle estimate off by 3 percentage points, on the high side; the range from low to high includes it.
By their numbers in this assay, from the lowest: compounds 1 and 4 (each within the scatter of the next); then compounds 3 and 2 (each within the scatter of the next).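

In this assay, for the compounds shown here, placing bromo in place of chloro on the aromatic carbon para to the hydroxy group gives a number 3 percentage points higher from compound 1 to compound 4 (within the scatter), the first comparison here that isolates a single position. At this position, then, compound 1 and compound 4 cannot be told apart, so the choice between these two halogens leaves no measurable mark on the read-out. No independent measurement bears on why the two halogens read alike.

Still open, on these data alone, is whether a group of another kind at this same position, such as an amine or a carboxylic acid, would separate itself from chloro and bromo. Also open, as far as these compounds go, is whether the same halogen exchange would read alike at the other chloro, which compound 1 and compound 4 share.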